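The source may hold more compounds than are shown below. What is called first, only, known or untested is meant among the compounds shown, and "the series" means these compounds.

Measured compounds:

- Compound 1, `CCCCCCCCCCCCCCNC(=O)C(CO[C@@H]1O[C@H](CO)[C@H](O)[C@H](O)[C@H]1O)NC(=O)CCC(=O)NCCS(=O)(=O)O`: > 100000 nM in a functional assay on CEM-SS cells (Homo sapiens) for cytotoxicity; on this read-out lower numbers stand for higher toxicity in this test and higher numbers for lower toxicity in this test
- Compound 2, `CCCCCCCCCCCCCC(=O)NCC(NC(=O)CCCCCCCCCCCCC)C(=O)NCCN(CCNC(=O)C(O)C(O)C(O[C@@H]1O[C@H](CO)[C@H](O)[C@H](O)C1O)C(O)CO)CCNC(=O)C(O)C(O)C(O[C@@H]1O[C@H](CO)[C@H](O)[C@H](O)[C@H]1O)C(O)CO`: 44000 nM in this assay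
- Compound 3, `O=C(O)CCCCCCCCCCC(=O)N(CCCCCCCC(F)(F)C(F)(F)C(F)(F)C(F)(F)C(F)(F)C(F)(F)C(F)(F)C(F)(F)F)CCO[C@@H]1O[C@H](CO)[C@H](O)[C@H](O)[C@H]1O`: > 18000 nM in this assay

Compound 1 gives no number of its own in this assay: its value of > 100000 nM is a limit, the highest concentration tested, at which no half-maximal killing of the cells was seen (the limit of > 100000 nM in this assay, at which 1 of the 3 values shown sits). The value of compound 3 is also a limit, > 18000 nM, so only compound 2 gives a real number, 44000 nM. Compound 1 therefore stands among the compounds with low toxicity in this test, and since no two of the three values are tied to each other by a single change, nothing can be said of the size of any step among them.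

Compound 4, `CCCCCCCCCCCCCCNC(=O)C(CO[C@@H]1O[C@H](CO)[C@H](O)[C@H](O)[C@H]1O)NC(=O)CCC(=O)O`, differs from compound 1 in one place: hydroxy in place of (2-sulfoethyl)amino on a carbonyl carbon. The shared core, the sugar and the long chain remain unchanged. Among the measured compounds shown here, with no comparable step among the measured compounds, the expectation for this change is a step of no more than the usual scatter, a number no higher from compound 1 to compound 4 (the limit leaves the size open), and most likely compound 4 is again only a limit. Compound 4 is expected to give 100000 nM in this assay, within 30000 nM to 300000 nM.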

Compound 4, half-maximal cytotoxic concentration: > 100000 nM
Compound 4: no number, only a limit; the forecaster's own chance of this, stated with the estimate: 85%; the middle value lies on the limit itself.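

No step can be read from compound 1 to compound 4: in this assay both give only a limit, not a number. The compounds shown leave open whether putting hydroxy in place of (2-sulfoethyl)amino changes the toxicity in this test at all, and by how much.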